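Swapping Difluoromethoxy for Dimethylamino

The source may report more compounds than this note shows. Statements on the series, on what has been measured and on what is new or still open speak of the compounds shown alone.

Measured so far in a functional assay on MCF-10A cells (Homo sapiens) for antiproliferative activity, with a stated time of 48 h; a lower number here means that less compound is needed, a higher number that more compound is needed for the effect:
- compound 1 `COc1ccc2nc(C)cc(NCc3ccccc3)c2c1`: 28600 nM
- compound 2 `COc1ccc2nc(C)cc(NCc3cccc(F)c3)c2c1`: 14700 nM
- compound 3 `COc1ccc2nc(C)cc(NCc3cccc(OC(F)F)c3)c2c1`: 14300 nM

The numbers do not clearly separate compound 3 from the other two. The data show a 2.0-fold lower number from compound 1 to compound 3 (0.30 log units; within the scatter) and a 1.0-fold lower number from compound 2 to compound 3 (0.01 log units; within the scatter).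

The next structure, compound 4 `COc1ccc2nc(C)cc(NCc3cccc(N(C)C)c3)c2c1`, keeps the shared core and has dimethylamino in place of difluoromethoxy on an aromatic carbon, meta to a large group (dimethylamino in place of difluoromethoxy on an aromatic carbon).

Among the measured compounds shown here, no measured step involves dimethylamino, so the guidance is indirect. For the measured compounds named here, the closest precedent is another exchange at this place, a 1.0-fold lower number from compound 2 to compound 3 (0.01 log units; within the scatter). Putting a group on the unsubstituted compound 1 also stayed small, with a 1.9-fold lower number from compound 1 to compound 2 (0.29 log units; within the scatter). A step beyond the scatter in this assay is therefore not expected, and no direction can be favoured. The expected step is a 1.0-fold higher number from compound 3 to compound 4 (0.02 log units; within the scatter). For compound 4 the estimated value is 15000 nM, with an expected range of 6500 nM to 35000 nM.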

Compound 4, half-maximal effective concentration: 14000 nM
The estimate for compound 4 lay 1.1-fold (0.03 log units) above the measured number; low and high end bracket the measured number.
By their numbers in this assay, from the lowest: compounds 4, 3, 2 and 1 (each within the scatter of the next, the first and the last beyond it).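

In this assay, putting dimethylamino at this place on the aromatic ring gives a 1.0-fold lower number from compound 3 to compound 4 (0.01 log units; within the scatter) and, against the fluoro analogue, a 1.1-fold lower number from compound 2 to compound 4 (0.02 log units; within the scatter), so a nitrogen-bearing group falls within the scatter of the fluorine-bearing groups. Against the unsubstituted parent, the change gives a 2.0-fold lower number from compound 1 to compound 4 (0.31 log units; beyond the scatter), the only step in this set beyond the scatter and only a modest one, while the steps from compound 1 to compound 2 and to compound 3 stay within it. No supporting evidence is available to explain this result.

As far as these compounds go, it remains open whether a carboxylic acid, a simple unsubstituted amine or a longer alkyl chain at this place would stay in the same range. Also unresolved is whether these groups would behave alike on the other carbons of this ring.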